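Aryl ester variation on a shared core: working notes

This account rests on a few compounds, and the source may have more. Where it says the series, first, only, none or still open, it means among the compounds named here.

Two esters of a shared core have been measured in a functional assay on MCF7 cells (Homo sapiens) for antiproliferative activity, read by sulforhodamine B assay, with a stated time of 48 h, tested at 50 uM; on this read-out higher numbers stand for more inhibition at the one concentration tested (going by the name of the read-out) and lower numbers for less inhibition. Compound 1 `Cc1cc2c(C(C)C)ccc(C)c2cc1OC(=O)c1ccc(C(F)(F)F)cc1` carries a 4-(trifluoromethyl)phenyl ester; in this assay compound 1 gives 16.8%. Compound 2 `COc1cccc(C(=O)Oc2cc3c(C)ccc(C(C)C)c3cc2C)c1` carries a 3-methoxyphenyl ester; in this assay compound 2 gives 31.8%. For the measured compounds named here, compound 2 thus stands highest of the two numbers so far, and its nearest neighbour, compound 1, lies lower by a margin beyond the usual scatter. Going by the values given here, no step between two measured compounds differing in a single place has been recorded, so the contribution of the aryl ester alone is not yet isolated.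

Compound 3 `Cc1cc2c(C(C)C)ccc(C)c2cc1OC(=O)c1ccc([N+](=O)[O-])cc1` is the next member. Its difference from compound 2 is 4-nitrophenyl in place of 3-methoxyphenyl on a carbonyl carbon. Among the compounds with values here, with only two numbers in hand, the expectation rests on the spread between compound 1 at 16.8% and compound 2 at 31.8%: a second 4-substituted aryl ester is expected to land nearer the lower of the two. The expected step, a number 9.8 percentage points lower from compound 2 to compound 3 (within the scatter), is downward and of a size close to the edge of the scatter. Compound 3 is estimated at 22%, with a range from 8% to 40%.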

Compound 3, a percentage reported as inhibition, at one concentration (the size of the read-out at that concentration, not a potency): 100%
Beside the measured number, compound 3's estimate is 78 percentage points below it; the measured number lies above the stated range.
By their numbers in this assay, from the lowest: compound 1; then compound 2; then compound 3.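

In this assay, the ester aryl group now has its first readings that differ in a single place: nitro in place of trifluoromethyl on an aromatic carbon gives a number 83.2 percentage points higher from compound 1 to compound 3 (beyond the scatter) with the rest of the molecule unchanged, so this one substituent alone can separate a low number from the top of the series. The second reading, 4-nitrophenyl in place of 3-methoxyphenyl on a carbonyl carbon, gives a number 68.2 percentage points higher from compound 2 to compound 3 (beyond the scatter) and shows that compound 3 stands apart from both other esters of the shared core, while the 4-(trifluoromethyl)phenyl ester of compound 1 shows that a group at the same ring position does not by itself bring this result. Nothing at hand accounts for the size of these two steps.

As far as these compounds go, since compound 3 gives 100% at one concentration, these readings give no potency, and how it would rank at lower concentrations remains open. Also open, from the compounds shown here alone, is whether a nitrile, an amine or a carboxylic acid on the same aromatic carbon would keep the high number, and whether an amide in place of the ester would do so.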